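A limit value and the next side-chain change

The compounds below may be only part of what the source reports. "The series", "measured", "known", "first", "only" and "open" are said of these compounds alone.

In a physicochemical assay for lipophilicity, at pH 7.4 (a higher number here means a more lipophilic compound, a lower number a more polar compound), compound 1 `Cc1cc(C(=O)Nc2ccc(F)cc2)nn1Cc1cc(Cl)ccc1OCc1ccccc1` gives 3. Compound 2 `Cc1cc(C(=O)NCc2ccncc2)nn1Cc1cc(Cl)ccc1OCc1ccccc1` gives > 3.7, which is a limit of the assay and not a number. Going by the values given here, the only measured step is a number at least 0.70 log units higher from compound 1 to compound 2 (beyond the scatter), and it altered the same side chain that changes next. Compound 3 `Cc1cc(NC(=O)CC2CCCCC2)nn1Cc1cc(Cl)ccc1OCc1ccccc1` differs from compound 2 as follows: ((cyclohexylmethyl)carbonyl)amino in place of ((pyridin-4-yl)methyl)carbamoyl on an aromatic carbon. Among the compounds with values here, with ((cyclohexylmethyl)carbonyl)amino in place of ((pyridin-4-yl)methyl)carbamoyl on an aromatic carbon, and only that one step as a guide, a modest further rise is expected, a step that the limit leaves unreadable from compound 2 to compound 3. Compound 3 is estimated at 4.1 in this assay, with an expected range of 3.5 to 4.7.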

Compound 3, distribution coefficient: 3.2
Estimate against measurement, compound 3: 0.90 log units above; the whole stated range lies above it.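

In this assay, ((cyclohexylmethyl)carbonyl)amino on this aromatic carbon gives a number at least 0.50 log units lower from compound 2 to compound 3 (beyond the scatter), so a side chain ending in a ring of carbon only does not carry the reading up here. Set against (4-fluorophenyl)carbamoyl, the same group gives a number 0.20 log units higher from compound 1 to compound 3 (within the scatter), so these two side chains cannot be told apart in this assay. For compound 2 the reading is a limit of the assay and not a number: the limit of > 3.7 in this assay, at which 1 of the 3 values shown sits.

As far as these compounds go, the true size of that first step stays open. Also open, from the compounds shown here alone, is how an amine or a carboxylic acid on this carbon, or a longer chain in place of cyclohexylmethyl, would read.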